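The source may hold more compounds than are shown below. What is called first, only, known or untested is meant among the compounds shown, and "the series" means these compounds.

Measured so far in a functional assay on CHO cells for agonist activity at Alpha-2B adrenergic receptor (Homo sapiens); a higher number here means that more compound is needed for the effect, a lower number that less compound is needed:
compound 1 `CCc1ccccc1OC(C)C1=NCCN1`: 10000 nM
compound 2 `CC(C)Oc1ccccc1OC(C)C1=NCCN1`: 1740 nM
compound 3 `CC(Oc1ccccc1OC1CC1)C1=NCCN1`: 12900 nM

Compound 3 has the highest of the three numbers in this assay. Its nearest neighbour is compound 1, which differs from it only within the scatter a 1.3-fold higher number from compound 1 to compound 3 (0.11 log units; within the scatter); its furthest is compound 2 a 7.4-fold higher number from compound 2 to compound 3 (0.87 log units; beyond the scatter).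

Compound 4 `CC(Oc1ccccc1C=O)C1=NCCN1` arises from compound 3 by a change at one aromatic carbon: formyl in place of cyclopropyloxy on an aromatic carbon. Going by the values given here, three measured steps touch this position. Replacing ethyl by isopropoxy a 5.7-fold lower number from compound 1 to compound 2 (0.76 log units; beyond the scatter) and replacing isopropyl by cyclopropyl on the oxygen a 7.4-fold higher number from compound 2 to compound 3 (0.87 log units; beyond the scatter) moved the number by modest amounts in opposite directions, while replacing ethyl by cyclopropyloxy a 1.3-fold higher number from compound 1 to compound 3 (0.11 log units; within the scatter) did not move it beyond the scatter. None of these steps introduces a formyl, so the direction for compound 4 is open; the measured spread at this position is modest, and a step of about that size in either direction, or none beyond the scatter, seems plausible. Compound 4 is therefore expected to give roughly 8000 nM, with a range from 2000 nM to 30000 nM, a step of a 1.6-fold lower number from compound 3 to compound 4 (0.21 log units; within the scatter) from compound 3 that is expected rather than known.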

Compound 4, half-maximal effective concentration: 316 nM
For compound 4 the middle estimate is 25-fold (1.40 log units) above the measured one; measured number below the stated range.
By their numbers in this assay, from the lowest: compound 4; then compound 2; then compounds 1 and 3 (each within the scatter of the next).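

In this assay, formyl in place of cyclopropyloxy (a 41-fold lower number from compound 3 to compound 4 (1.61 log units; beyond the scatter)) and formyl in place of ethyl (a 32-fold lower number from compound 1 to compound 4 (1.50 log units; beyond the scatter)) are both large steps, showing that this aromatic carbon allows much bigger changes than the modest ones seen earlier. Formyl also goes beyond isopropoxy, the best group until now (a 5.5-fold lower number from compound 2 to compound 4 (0.74 log units; beyond the scatter)), which places compound 4 lowest of the four even though formyl has fewer heavy atoms than cyclopropyloxy and no ring. Nothing available gives a measured reason for these steps.

Going by these compounds, it remains open whether the low number belongs to formyl alone or extends to related groups on the same aromatic carbon, such as acetyl, a carboxylic acid or an amide. On these data alone, it is also open whether formyl would give a similar step on a core changed elsewhere.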